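The compounds below may be only part of what the source reports. "The series", "measured", "known", "first", "only" and "open" are said of these compounds alone.

Measured so far:
compound 1, `CNC1CC(=O)OC1C(O)C(=O)NC(CC(C)C)C1Cc2cccc(O)c2C(=O)O1`, 1500 ug/mL;
compound 2, `CCCCNC1CC(=O)OC1C(O)C(=O)NC(CC(C)C)C1Cc2cccc(O)c2C(=O)O1`, 100000 ug/mL.

In a physicochemical assay for solubility (a lower number here means a less soluble compound, a higher number a more soluble compound), compound 2 stands highest of the two numbers shown; its nearest neighbour is compound 1, and the step of a 67-fold higher number from compound 1 to compound 2 (1.82 log units; beyond the scatter) is beyond the scatter. Compound 3, `CCCCCNC1CC(=O)OC1C(O)C(=O)NC(CC(C)C)C1Cc2cccc(O)c2C(=O)O1`, has not yet been measured. It differs from compound 2 by methyl in place of hydrogen on a saturated chain carbon, four bonds along the chain from an amine nitrogen.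

Among the compounds with values here, only one measured step bears on this change: the step of a 67-fold higher number from compound 1 to compound 2 (1.82 log units; beyond the scatter), which was large and ran in the direction of a longer chain. The change from compound 2 to compound 3 is smaller in kind, one further carbon on an already long chain, and compound 2 already holds the highest number in this assay. The step from compound 2 to compound 3 is therefore expected to be modest, a 1.3-fold lower number from compound 2 to compound 3 (0.10 log units; within the scatter), not clearly beyond the scatter. Compound 3 is estimated at 80000 ug/mL, within the range 20000 ug/mL to 160000 ug/mL.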

Compound 3, solubility: 7300 ug/mL
Compound 3: middle estimate off by 11-fold (1.04 log units), on the high side; the measured number lies below the stated range.
By their numbers in this assay, from the lowest: compound 1; then compound 3; then compound 2.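

In this assay, methyl in place of hydrogen on a saturated chain carbon, four bonds along the chain from an amine nitrogen, gave a 14-fold lower number from compound 2 to compound 3 (1.14 log units; beyond the scatter), so one added carbon at this place can produce a large step. The longest chain shown nevertheless keeps a modest gain over the shortest, with a 4.9-fold higher number from compound 1 to compound 3 (0.69 log units; beyond the scatter), and thus the numbers of these three compounds do not climb steadily with chain length: compound 3 falls out of any such order. Nothing measured here accounts for this reversal.

As far as these compounds go, what remains open is whether a longer chain on that amine nitrogen would lower the number further or raise it again. The compounds shown also leave open how an ethyl or propyl chain at the same nitrogen would fall within this sequence.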